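The source may report more compounds than this note shows. Statements on the series, on what has been measured and on what is new or still open speak of the compounds shown alone.

The series begins with three measured hydrazone-thiazoles. Compound 1 `COc1cc(/C=N/Nc2nc(-c3ccccc3)cs2)c(Br)c(Br)c1OC` gives 15300 nM in a functional assay on A549 cells (Homo sapiens) for inhibition, read by MTT assay, with a stated time of 48 h; on this read-out higher numbers stand for weaker inhibition and lower numbers for stronger inhibition. Compound 3 `COc1cc(/C=N/Nc2nc(-c3cccc(Br)c3)cs2)c(Br)c(Br)c1OC` differs from compound 1 only on the aromatic ring attached to the shared core. Compound 3 gives 37000 nM, and the change amounts to a 2.4-fold higher number from compound 1 to compound 3 (0.38 log units; beyond the scatter). Compound 2 `Fc1ccc(/C=N/Nc2nc(-c3cc(C(F)(F)F)cc(C(F)(F)F)c3)cs2)cc1F` gives 6230 nM and stands lowest of the three numbers, beyond the scatter from both compound 1 and compound 3.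

The next compound to be measured is compound 4 `COc1cc(/C=N/Nc2nc(-c3cc(C(F)(F)F)cc(C(F)(F)F)c3)cs2)cc(Br)c1OC`. It differs from compound 2 in one place: 3-bromo-4,5-dimethoxyphenyl in place of 3,4-difluorophenyl on a carbon with a double bond to nitrogen. Within the data shown here, no measured step bears directly on this change; the only step in hand, from compound 1 to compound 3, concerns the other aromatic ring. Compounds 1 and 3, which carry a dimethoxyphenyl bearing bromine at the same position, show weaker inhibition than compound 2, so a moderate rise in number is expected for compound 4, as a 1.8-fold higher number from compound 2 to compound 4 (0.25 log units; within the scatter). Compound 4 is therefore estimated at 11000 nM, within 4000 nM to 28000 nM.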

Compound 4, half-maximal inhibitory concentration: 94200 nM
Compound 4: middle estimate off by 8.6-fold (0.93 log units), on the low side; the whole stated range lies below it.
By their numbers in this assay, from the lowest: compound 2; then compound 1; then compound 3; then compound 4.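

In this assay, among these compounds, the aromatic ring on the carbon with a double bond to nitrogen proves to matter greatly: 3-bromo-4,5-dimethoxyphenyl in place of 3,4-difluorophenyl gives a 15-fold higher number from compound 2 to compound 4 (1.18 log units; beyond the scatter), a large step towards weaker inhibition, whereas the one earlier step, on the other aromatic ring, was modest. The earlier compounds shown here could not show this, since no earlier pair differed at this position. No measurement shown accounts for the size of this loss.

The change replaces both fluoro groups with a bromo and two methoxy groups at once, so the compounds shown leave open which of these carries the loss. They also leave open how this position would respond to a ring bearing an amine or a carboxylic acid.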